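Side chain change from compound 2 to compound 3

The compounds below may be only part of what the source reports. "The series", "measured", "known", "first", "only" and "open" are said of these compounds alone.

Measured in a functional assay on U-87MG ATCC cells (Homo sapiens) for antiproliferative activity, with a stated time of 3 days (on this read-out lower numbers stand for an effect already at smaller amounts and higher numbers for an effect only at larger amounts of compound), so far:
- compound 1 `Oc1ccc(CN(Cc2ccccc2C(F)(F)F)Cc2ccc(O)c3ncccc23)c2cccnc12` gives < 0.2 uM (a limit of the assay, not a number)
- compound 2 `Oc1ccc(CN(Cc2ccc(O)c3ncccc23)CC2CCCO2)c2cccnc12` gives 5 uM (the only actual number so far)

Compound 3 `Oc1ccc(CN(CCN2CCCC2)Cc2ccc(O)c3ncccc23)c2cccnc12` is next, and its difference from compound 2 reads (pyrrolidin-1-yl)methyl in place of oxolan-2-yl on a saturated chain carbon bound to an amine nitrogen (in words, (pyrrolidin-1-yl)methyl in place of oxolan-2-yl on a saturated chain carbon bound to an amine nitrogen). Among the measured compounds shown here, the one measured step at this place is an at least 25-fold higher number from compound 1 to compound 2 (1.39 log units; beyond the scatter) and it involved 2-(trifluoromethyl)phenyl, a different group from the one entering here. Compound 1 enters that step only through the limit of < 0.2 uM in this assay, at which 1 of the 2 values shown sits, and not through a number. Starting from compound 2 at 5 uM and with both groups holding one five-membered non-aromatic ring with 1 hetero atom, no step beyond the scatter is expected in this assay in either direction. The estimated outcome is a 1.3-fold lower number from compound 2 to compound 3 (0.10 log units; within the scatter) (an expectation only). For compound 3 the expected value is 4 uM with an estimated range from 1 uM to 15 uM (not yet measured).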

Compound 3, concentration for half-maximal effect: 0.2 uM
Compound 3: the middle estimate sits 20-fold (1.30 log units) above what was measured, and the stated range ends above it.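

In this assay, this place on the saturated chain carbon bound to an amine nitrogen responds strongly even when the ring type and the donor and acceptor counts stay the same: a 25-fold lower number from compound 2 to compound 3 (1.40 log units; beyond the scatter). The change from oxolan-2-yl to (pyrrolidin-1-yl)methyl also shows that 2-(trifluoromethyl)phenyl is not needed for a low number here, as compound 3 gives 0.2 uM. The comparison with compound 1 can be read only as a number no lower from compound 1 to compound 3 (the limit leaves the size open). The value of compound 1 is a limit and not a number: the limit of < 0.2 uM in this assay, at which 1 of the 3 values shown sits.

On these data alone, it stays open whether the step follows the ring nitrogen or the longer chain of 2-(pyrrolidin-1-yl)ethyl. A morpholine or an open-chain diethylamine at the end of the same chain would help separate these two readings.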